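The source may report more compounds than this note shows. Statements on the series, on what has been measured and on what is new or still open speak of the compounds shown alone.

Measured so far in a functional assay on HT-29 cells (Homo sapiens) for cytotoxicity, read by MTT assay, with a stated time of 72 h; on this read-out lower numbers stand for stronger inhibition and higher numbers for weaker inhibition:
- compound 1 `CN(C)CCn1cnnc1-c1cc(Oc2ccc(NC(=O)N/N=C/c3ccc(F)cc3)cc2F)ccn1` gives 1370 nM
- compound 2 `CN(C)CCn1cnnc1-c1cc(Oc2ccc(NC(=O)N/N=C/c3c(O)ccc4ccccc34)cc2F)ccn1` gives 670 nM
- compound 3 `CN(C)CCn1cnnc1-c1cc(Oc2ccc(NC(=O)N/N=C/c3cccc(Br)c3)cc2F)ccn1` gives 380 nM

Compound 3 has the lowest number of the three: against compound 1 the step is a 3.6-fold lower number from compound 1 to compound 3 (0.56 log units; beyond the scatter), while against compound 2 it is only a 1.8-fold lower number from compound 2 to compound 3 (0.25 log units; within the scatter). Compound 4 `CN(C)CCn1cnnc1-c1cc(Oc2ccc(NC(=O)N/N=C/c3cccc(O)c3)cc2F)ccn1` is the next step from compound 3: hydroxy in place of bromo on an aromatic carbon. Among the measured compounds shown here, no measured step swaps a halogen for a hydroxy on the same ring. The nearest guide is a 2.0-fold lower number from compound 1 to compound 2 (0.31 log units; beyond the scatter), where a hydroxy entered together with a second ring, and a 3.6-fold lower number from compound 1 to compound 3 (0.56 log units; beyond the scatter), where one halogen replaced another. On that basis compound 4 is expected to stay close to compound 3, with a step of a 1.6-fold higher number from compound 3 to compound 4 (0.20 log units; within the scatter) that need not exceed the scatter. The estimate for compound 4 is 600 nM, range 250 nM to 1500 nM.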

Compound 4, half-maximal inhibitory concentration: 330 nM
Compound 4: middle estimate off by 1.8-fold (0.26 log units), on the high side; measured number inside the range.
By their numbers in this assay, from the lowest: compounds 4, 3 and 2 (each within the scatter of the next, the first and the last beyond it); then compound 1.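

In this assay, 3-bromophenyl and 3-hydroxyphenyl cannot be told apart, with a 1.2-fold lower number from compound 3 to compound 4 (0.06 log units; within the scatter), although the change adds a hydrogen-bond donor and a hydrogen-bond acceptor. The 3-hydroxyphenyl group also compares well with the other two groups at this place, with a 2.0-fold lower number from compound 2 to compound 4 (0.31 log units; beyond the scatter) and a 4.2-fold lower number from compound 1 to compound 4 (0.62 log units; beyond the scatter). Nothing available explains these differences.

Open, on these data alone, is how an amine or a carboxylic acid in place of the hydroxy on this ring would read in this assay. Also open, as far as these compounds go, is whether a methoxy group would match the hydroxy.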